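The source may hold more compounds than are shown below. What is called first, only, known or untested is meant among the compounds shown, and "the series" means these compounds.

Measured in a functional assay on HL-60 cells (Homo sapiens) for antiproliferative activity, read by MTT assay; on this read-out lower numbers stand for stronger inhibition and higher numbers for weaker inhibition:
- compound 1 `CC[C@H]1O[C@H](COCc2ccccc2)[C@@H](OCc2ccccc2)[C@H](OCc2ccccc2)[C@H]1O`: "not active" (no number reported)
- compound 2 `C=CC[C@@H]1O[C@H](COCc2ccccc2)[C@@H](OCc2ccccc2)[C@H](OCc2ccccc2)[C@H]1O`: 15100 nM
- compound 3 `C=CC[C@@H]1O[C@H](COCc2ccccc2)[C@@H](OCc2ccccc2)[C@H](OCc2ccccc2)[C@H]1OC(C)=O`: 26900 nM

Only two of these compounds have a number. Compound 2 gives 15100 nM, and compound 3 lies within the scatter of it, so the data do not separate the two. Compound 1 gives "not active" (no number reported), so it cannot be placed on the same scale.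

The next compound to be tested is compound 4 `CC[C@@H]1O[C@H](COCc2ccccc2)[C@@H](OCc2ccccc2)[C@H](OCc2ccccc2)[C@H]1O`. The change is methyl in place of vinyl on a saturated chain carbon bound to a saturated ring carbon: methyl in place of vinyl, which can also be read as allyl to ethyl.

Among the measured compounds shown here, no measured step covers this change. The only one available, acetyl in place of hydrogen on an oxygen on a saturated carbon, is a 1.8-fold higher number from compound 2 to compound 3 (0.25 log units; within the scatter) and stays within the scatter. It shows that one change elsewhere on compound 2 left the number in this assay unresolved, but it says little about the vinyl group. Compound 1, at "not active" (no number reported), is a reminder that a result without a number is possible, so the expectation leans towards weaker inhibition.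

The expected change is small, and a 2.0-fold higher number from compound 2 to compound 4 (0.30 log units; within the scatter) is the estimated step. For compound 4 the estimated value is 30000 nM, with an expected range of 13000 nM to 80000 nM.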

Compound 4, half-maximal inhibitory concentration: 8200 nM
Compound 4: middle estimate off by 3.7-fold (0.56 log units), on the high side; the measured number lies below the stated range.
By their numbers in this assay, from the lowest: compounds 4, 2 and 3 (each within the scatter of the next, the first and the last beyond it).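

In this assay, the change from allyl to ethyl, on a saturated chain carbon bound to a saturated ring carbon, is a small one: the result is a 1.8-fold lower number from compound 2 to compound 4 (0.27 log units; within the scatter) and the data do not separate the two compounds. Compound 4 has no double bond outside its aromatic rings and still gives a number, so a vinyl end on this chain is not needed for measurable activity in this assay. Compound 1 carries the same ethyl group yet gives "not active" (no number reported) while compound 4 gives 8200 nM, so the ethyl group alone does not decide the outcome, and the difference between the two compounds comes down to this: the fact that compounds 1 and 4 differ only in the configuration as drawn.

The compounds shown leave open whether the configuration as drawn would matter in the same way with allyl in place of ethyl, since that comparison has only one side here. They also leave open how this position would respond to a longer chain, an amine or a carboxylic acid, as only allyl and ethyl appear there.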